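A Further Hydroxy Group on Compound 3

The source may report more compounds than this note shows. Statements on the series, on what has been measured and on what is new or still open speak of the compounds shown alone.

In a functional assay on NCI-H1299 cells (Homo sapiens) for antiproliferative activity, read by fluorescence and resazurin assay, with a stated time of 48 h (a higher number here means a weaker inhibitor, a lower number a stronger inhibitor), compound 1 (`COc1ccc(Cn2cc(-c3ccc(O)cc3)c(-c3ccc(O)cc3)c2)c(OC)c1`) gives 31600 nM and compound 2 (`COc1ccc(Cn2cc(-c3ccc(O)cc3)c(-c3ccc(O)cc3)c2)c(OC)c1OC`) gives 25100 nM while compound 3 (`COc1ccc(-c2cn(Cc3ccc(O)cc3)cc2-c2ccc(OC)cc2)cc1`) gives 20500 nM as its value. Compound 3 lies within the scatter of both compound 1 and compound 2, so these numbers do not separate the three.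

Compound 4 (`COc1ccc(-c2cn(Cc3ccc(O)c(O)c3)cc2-c2ccc(OC)cc2)cc1`) differs from compound 3 in one place. The change, (hydroxy in place of hydrogen on an aromatic carbon), turns 4-hydroxybenzyl into 3,4-dihydroxybenzyl, with hydroxy in place of hydrogen on an aromatic carbon, ortho to a hydroxy group.

Among the compounds with values here, no measured step adds a hydroxy group, so the data offer no direct precedent. Within the data shown here, the one measured step between close neighbours (a 1.3-fold lower number from compound 1 to compound 2 (0.10 log units; within the scatter)) puts methoxy in place of hydrogen on an aromatic carbon, a different group, and it stays within the scatter. On that step alone, no shift beyond the scatter is expected in this assay for compound 4, although a modest move toward a lower number remains possible. The estimate therefore means a 1.3-fold lower number from compound 3 to compound 4 (0.11 log units; within the scatter) and no more. For compound 4 the estimated value is 16000 nM with an expected range from 6000 nM to 32000 nM in this read-out.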

Compound 4, half-maximal inhibitory concentration: 19100 nM
The estimate for compound 4 lay 1.2-fold (0.08 log units) below the measured number, and the stated range covers the measured number.
By their numbers in this assay, from the lowest: compounds 4, 3, 2 and 1 (each within the scatter of the next).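

In this assay the step of a 1.1-fold lower number from compound 3 to compound 4 (0.03 log units; within the scatter) shows that hydroxy in place of hydrogen on an aromatic carbon, ortho to a hydroxy group, does not separate the two compounds, so 4-hydroxybenzyl and 3,4-dihydroxybenzyl cannot be told apart by this read-out. Within the data shown here, the earlier compounds could not show this, since their only step, a 1.3-fold lower number from compound 1 to compound 2 (0.10 log units; within the scatter), introduced methoxy and no step among them introduced hydroxy; the new step extends the picture to a second group and to the benzyl group of compound 3, and it too stays within the scatter. No evidence beyond these antiproliferative numbers bears on the result, so it stands as an observation without an explanation.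

On these data alone, whether an amine, a carboxylic acid or a longer chain at this same place on the benzyl group would move the number beyond the scatter remains open. Also open, as far as these compounds go, is whether hydroxy at this place would give a similarly small step on the more heavily methoxylated benzyl groups of compound 1 and compound 2.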